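Aryl ether urea series: halogen swap on the phenoxy ring

This account rests on a few compounds, and the source may have more. Where it says the series, first, only, none or still open, it means among the compounds named here.

Compound 1 (`COc1ccccc1NC(=O)N[C@H]1CC[C@H](Oc2ccc(F)cc2)CC1`) sets the weak end of the set. Within the data shown here, in a functional assay on CRL2813 cells (Homo sapiens) for cytotoxicity, read by sulforhodamine B assay, with a stated time of 5 days (on this read-out lower numbers stand for stronger inhibition and higher numbers for weaker inhibition), compound 1 returns only a limit, > 20000 nM, and that limit is the single piece of evidence on this series beyond one number (the limit of > 20000 nM in this assay, at which 1 of the 2 values shown sits). Among the measured compounds shown here, compound 2 (`O=C(Nc1cccc(C(F)(F)F)c1)N[C@H]1CC[C@H](Oc2cccc(F)c2)CC1`) is the one compound with a measured number: in this assay compound 2 gives 2400 nM, so it stands as the only quantified point. Nothing else in the set offers a number to rank it against. For the measured compounds named here, no step between two measured compounds is available here, and the two values shown cannot be turned into one, as compound 1 and compound 2 differ in more than one place.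

Compound 3 (`O=C(Nc1cccc(C(F)(F)F)c1)N[C@H]1CC[C@H](Oc2ccc(Cl)cc2)CC1`) is the next entry, made from compound 2 by 4-chlorophenyl in place of 3-fluorophenyl on an oxygen on a saturated carbon. With no measured step of this kind in the series, the expectation for this assay is a change of small size in either direction, likely not beyond the scatter. The step from compound 2 to compound 3 is estimated at a 1.2-fold lower number from compound 2 to compound 3 (0.08 log units; within the scatter). For compound 3 the expected value in this assay is 2000 nM, with a range from 600 nM to 7000 nM.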

Compound 3, half-maximal inhibitory concentration: 2000 nM
The estimate for compound 3 equals the measured number at the digits printed; measured number inside the range.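

In this assay, among these compounds, the exchange of 3-fluorophenyl for 4-chlorophenyl, on an oxygen on a saturated carbon, gives a 1.2-fold lower number from compound 2 to compound 3 (0.08 log units; within the scatter), which is the first step that can be read. With the rest of the core of compound 2 held fixed, this single reading shows that the halogen and its ring position can change together at this place without a step that stands beyond the scatter, and the series now has a second quantified compound. Nothing shown gives a reason for this outcome or bears on it.

The halogen and its ring position changed in the same step, so the effect of each remains unresolved, and 3-chlorophenyl and 4-fluorophenyl on the core of compound 2 would be needed to separate them; steps to compound 1 cannot be read, as it differs from both other compounds in more than one place and its value is a limit. Also open, on these data alone, is how this position responds to groups other than halogens, such as a nitrile, an amine or a carboxylic acid on the phenoxy ring.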